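Cytotoxicity notes on compound 1 and compound 4

The compounds below may be only part of what the source reports. "The series", "measured", "known", "first", "only" and "open" are said of these compounds alone.

Compound 1 `COc1cc2ncnc(-n3nc(-c4ccccn4)nc3N)c2cc1[N+](=O)[O-]` has been run in an ADME assay on BJ cells (Homo sapiens) for cytotoxicity, with a stated time of 72 h; on this read-out lower numbers stand for an effect already at smaller amounts and higher numbers for an effect only at larger amounts of compound. In this assay compound 1 gives > 13000 nM, which is a limit of the assay rather than a number. Compound 3 `Nc1nc(-c2ccccn2)nn1-c1ncnc2cc(OC(F)(F)F)ccc12` has also been tested; in this assay compound 3 gives > 13000 nM, again a limit and not a number. Compound 2 `Nc1nc(-c2ccccn2)nn1-c1ncnc2cc(N3CCNCC3)c([N+](=O)[O-])cc12` is recorded in this assay as "not determined" (no result reported). Compound 1 therefore stands only at a limit, with one further value shown also a limit and one entry carrying no number; the picture is set by the limit of > 13000 nM in this assay, at which 2 of the 3 values shown sit.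

Compound 4 `CCOC(=O)NCCCOc1cc2c(-n3nc(-c4ccccn4)nc3N)ncnc2cc1OC` remains to be measured in this assay. The change from compound 1 is 3-((ethoxycarbonyl)amino)propoxy in place of nitro on an aromatic carbon. For the measured compounds named here, no step between two measured compounds is available in this set, so no measured size of change can be quoted.

For compound 4 the expectation is that the limit of compound 1 is kept and that no step beyond the scatter appears, a change of a step that the limit leaves unreadable from compound 1 to compound 4 being estimated, since both values shown with a number sit at the limit of > 13000 nM in this assay, at which 2 of the 3 values shown sit. Compound 4 is accordingly estimated at 20000 nM, within a range from 8000 nM to 60000 nM.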

Compound 4, half-maximal effective concentration: > 11000 nM
Compound 4: no number, only a limit; the forecaster's own chance of this, stated with the estimate: 80%; the middle value lies beyond the limit too.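

In this assay compound 4 gives > 11000 nM, a limit of the assay and not a number. For the compounds shown here, compound 1 also stands at a limit, so no step from compound 1 to compound 4 can be read. The compounds shown leave open at which concentration, if any, compound 1 or compound 4 reaches a half-maximal effect on these cells.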